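Chloro for fluoro on the fluorophenyl ring of compound 2

A few compounds are considered here, and "the series" means these few. Any claim that something is new, unique, unknown or untested is made for them only; others in the source may bear on it.

Measured compounds:
- compound 1 `C/C(=N/NC(=O)Nc1nc(-c2ccc(C)cc2)cc(-c2ccc(F)cc2)n1)c1ccc([N+](=O)[O-])cc1` gives 300 mg/kg in a functional assay on the whole organism (strain Albino) with Mus musculus as the target, with a stated time of 4 h; on this read-out lower numbers stand for an effect already at smaller amounts and higher numbers for an effect only at larger amounts of compound
- compound 2 `C/C(=N/NC(=O)Nc1nc(-c2ccc(C)cc2)cc(-c2ccc(F)cc2)n1)c1ccc(Cl)cc1` gives 100 mg/kg in this assay
- compound 3 `COc1ccc(-c2cc(-c3ccc(Cl)cc3)nc(NC(=O)N/N=C\c3cccc(Cl)c3)n2)cc1OC` gives 300 mg/kg in this assay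

Among these three, compound 2 has the lowest number; compound 1 and compound 3 each stand above it by a step beyond the scatter. Compound 4 `C/C(=N/NC(=O)Nc1nc(-c2ccc(C)cc2)cc(-c2ccc(Cl)cc2)n1)c1ccc(Cl)cc1` differs from compound 2 by chloro in place of fluoro on an aromatic carbon. Among the measured compounds shown here, the only measured single change, a 3.0-fold lower number from compound 1 to compound 2 (0.48 log units; beyond the scatter), swaps a different group on a different ring, so it bears on this step only loosely. For the measured compounds named here, no measured pair shows a chloro-for-fluoro exchange, so no step beyond the scatter is expected in this assay. Compound 4 is therefore estimated at 100 mg/kg, within 50 mg/kg to 200 mg/kg, corresponding to an expected no change at the digits printed from compound 2 to compound 4 (within the scatter).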

Compound 4, dose for half-maximal effect: 300 mg/kg
Estimate against measurement, compound 4: 3.0-fold (0.48 log units) below; measured number above the stated range.
By their numbers in this assay, from the lowest: compound 2; then compounds 1, 3 and 4 (each within the scatter of the next).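

The earlier compounds shown here showed a change on the other aryl ring only; this result shows that the 4-fluorophenyl ring also matters in this assay, with 4-chlorophenyl in place of 4-fluorophenyl giving a 3.0-fold higher number from compound 2 to compound 4 (0.48 log units; beyond the scatter). Exchanging one halogen for another, with no hydrogen-bond donors, acceptors or net charge involved, is enough to move the dose beyond the scatter. Nothing available explains this shift. Going by these compounds, whether an amine or a carboxylic acid at this carbon would keep the lower number of compound 2 remains open. So does whether a hydrogen there would.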